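The source may report more compounds than this note shows. Statements on the series, on what has been measured and on what is new or still open speak of the compounds shown alone.

Of the compounds shown here, two have so far been measured in a functional assay on HCT-116 cells (Homo sapiens) for inhibition, read by sulforhodamine B assay, with a stated time of 72 h; a lower number here means a stronger inhibitor, a higher number a weaker inhibitor. Compound 1 `COc1ccc2cc(C(C)c3nnc4n3N=C(c3ccc([N+](=O)[O-])cc3)CS4)ccc2c1` gives 15100 nM in this assay. Compound 2 `CC(C)Cc1ccc(C(C)c2n[nH]c(=S)n2N)cc1` gives 27400 nM in this assay. Compound 1 has the lower of the two numbers, but the gap to compound 2 lies within the usual scatter of repeated measurements, so on these figures the two cannot be told apart. Within the data shown here, no pair of measured compounds differing in only one place is available, so no measured step exists to lean on.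

Compound 3 `COc1ccc2cc(C(C)c3nnc4n3N=C(c3ccc(F)cc3)CS4)ccc2c1` has not yet been measured. It differs from compound 1 in one place: fluoro in place of nitro on an aromatic carbon. Cut one bond further out, the same difference reads 4-nitrophenyl to 4-fluorophenyl.

Among the measured compounds shown here, nothing among the measured compounds shows how a swap of this kind moves the number in this assay; the expected step is therefore a 1.2-fold higher number from compound 1 to compound 3 (0.08 log units; within the scatter), a small one, in neither direction beyond the scatter. Compound 3 is expected to give 18000 nM in this assay, with a range from 6000 nM to 55000 nM.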

Compound 3, half-maximal inhibitory concentration: 13100 nM
Beside the measured number, compound 3's estimate is 1.4-fold (0.14 log units) above it, and the stated range covers the measured number.
By their numbers in this assay, from the lowest: compounds 3, 1 and 2 (each within the scatter of the next, the first and the last beyond it).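

In this assay, among these compounds, fluoro in place of nitro on the aromatic carbon para to a large group gives a 1.2-fold lower number from compound 1 to compound 3 (0.06 log units; within the scatter), and this is the first measured step in which only one place differs. It shows that the three heavy atoms of the nitro group, with its two hydrogen-bond acceptors, can give way to a single fluorine atom at this position with no shift that can be told from the scatter, so on this one pair neither group stands out from the other. Nothing measured here explains why the two groups read alike.

This single pair says nothing about whether the number would move with a quite different group on that carbon, such as an amine, a carboxylic acid or a longer chain, or with a bare hydrogen atom there. It also leaves open whether any one-place change to the core of compound 1, at this position or elsewhere, can carry the number beyond the scatter at all.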